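Unsubstituted benzyl thioether: expected potency in the series

The source may hold more compounds than are shown below. What is called first, only, known or untested is meant among the compounds shown, and "the series" means these compounds.

Compound 2 `Clc1ccccc1CSc1nnc(-c2ccncc2)n1-c1ccccc1` carries the 2-chlorobenzyl thioether on the shared core, and in a functional assay on HCT-116 cells (Homo sapiens) for inhibition, read by MTT assay, with a stated time of 48 h (a lower number here means a stronger inhibitor, a higher number a weaker inhibitor), compound 2 gives 13900 nM. Among the compounds with values here, this is the highest of the three numbers measured so far, yet it sits within the scatter of both others: compound 1 `Fc1ccccc1CSc1nnc(-c2ccncc2)n1-c1ccccc1`, the 2-fluorophenyl analogue, gives 12000 nM, and compound 3 `Brc1ccc(CSc2nnc(-c3ccncc3)n2-c2ccccc2)cc1`, the 4-bromophenyl analogue, gives 11100 nM. The steps among them are all small, a 1.2-fold higher number from compound 1 to compound 2 (0.06 log units; within the scatter), a 1.1-fold lower number from compound 1 to compound 3 (0.03 log units; within the scatter) and a 1.3-fold lower number from compound 2 to compound 3 (0.10 log units; within the scatter), and none rises above the scatter.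

Within the data shown here, compound 4 `c1ccc(CSc2nnc(-c3ccncc3)n2-c2ccccc2)cc1` is the unmeasured member. hydrogen in place of chloro on an aromatic carbon This removes the halogen altogether rather than exchanging one halogen for another, so no measured pair matches it exactly. Among the measured compounds shown here, the steps that bear on it are the halogen swaps, chloro in place of fluoro with a 1.2-fold higher number from compound 1 to compound 2 (0.06 log units; within the scatter) and 4-bromophenyl in place of 2-chlorophenyl with a 1.3-fold lower number from compound 2 to compound 3 (0.10 log units; within the scatter), both within the scatter. Since the three compounds differ so little in this assay, the expected step from compound 2 to compound 4 is none beyond the scatter, a 1.1-fold lower number from compound 2 to compound 4 (0.03 log units; within the scatter), with the range widened because removal of the halogen is not covered by any measured pair. Compound 4 is therefore estimated at 13000 nM in this assay, within 6500 nM to 26000 nM.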

Compound 4, half-maximal inhibitory concentration: 16900 nM
Estimate against measurement, compound 4: 1.3-fold (0.11 log units) below, and the stated range covers the measured number.
By their numbers in this assay, from the lowest: compounds 3, 1, 2 and 4 (each within the scatter of the next).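

Hydrogen in place of a halogen on this aromatic ring gives no step beyond the scatter in this assay, whether the halogen replaced is chloro (a 1.2-fold higher number from compound 2 to compound 4 (0.08 log units; within the scatter)), bromo (a 1.5-fold higher number from compound 3 to compound 4 (0.18 log units; within the scatter)) or fluoro (a 1.4-fold higher number from compound 1 to compound 4 (0.15 log units; within the scatter)). The earlier compounds only exchanged one halogen for another, whereas compound 4 has none, so the reading now extends to the plain benzyl thioether: among these four compounds, the presence of a halogen on this ring does not separate any compound from compound 4 in this assay. Nothing available offers an explanation for this flat reading.

The compounds shown carry only hydrogen, fluoro, chloro or bromo on this ring, so it remains open whether an amine, a carboxylic acid or a methoxy group there would give a step beyond the scatter, and whether a longer chain in place of the benzyl group would do so. Also open, on these data alone, is how one halogen behaves at different places on the ring, since 2-chlorophenyl, 2-fluorophenyl and 4-bromophenyl differ in both the halogen and its place.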